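The source may hold more compounds than are shown below. What is called first, only, known or untested is meant among the compounds shown, and "the series" means these compounds.

Measured so far in a functional assay on MCF7 cells (Homo sapiens) for cytotoxicity, read by sulforhodamine B assay, with a stated time of 48 h; on this read-out lower numbers stand for stronger inhibition and higher numbers for weaker inhibition:
- compound 1 `C/C(=N\NC(=O)c1sc(N)c(C#N)c1N)c1ccc(S(=O)(=O)N2CCCCC2)cc1`: 49300 nM
- compound 2 `C/C(=N\NC(=O)c1sc2c(c1N)CCC2)c1ccc(S(=O)(=O)N2CCCCC2)cc1`: 75300 nM

For the measured compounds named here, compound 2 stands at the highest of the two numbers in this assay, with compound 1 as its only neighbour; the step of a 1.5-fold higher number from compound 1 to compound 2 (0.18 log units; within the scatter) lies within the scatter, so the two compounds are not separated by the read-out.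

Compound 3 `C/C(=N\NC(=O)c1sc2c(c1N)CCCC2)c1ccc(S(=O)(=O)N2CCCCC2)cc1` is not yet measured. It differs from compound 2 by a group of 10 heavy atoms (8 carbon, 1 nitrogen, 1 sulfur; one five-membered aromatic ring with 1 hetero atom, one six-membered non-aromatic ring of carbon only) in place of a group of 9 heavy atoms (7 carbon, 1 nitrogen, 1 sulfur; one five-membered non-aromatic ring of carbon only, one five-membered aromatic ring with 1 hetero atom), on a carbonyl carbon. Going by the values given here, the only measured step at that carbonyl carbon is a 1.5-fold higher number from compound 1 to compound 2 (0.18 log units; within the scatter), which exchanged a different pair of groups and did not move the number beyond the scatter. Among the compounds with values here, no measured step covers a change from a five-membered to a six-membered non-aromatic ring of carbon only, so the expectation rests on that one step alone. On that basis the expected step is a 1.1-fold lower number from compound 2 to compound 3 (0.03 log units; within the scatter), that is nothing beyond the scatter. Compound 3 is therefore expected to give about 70000 nM in this assay, with a range from 25000 nM to 200000 nM.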

Compound 3, half-maximal inhibitory concentration: 87800 nM
For compound 3 the middle estimate is 1.3-fold (0.10 log units) below the measured one, and the stated range covers the measured number.
By their numbers in this assay, from the lowest: compounds 1, 2 and 3 (each within the scatter of the next).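

In this assay, putting the six-membered non-aromatic ring of carbon only in place of the five-membered one on the carbonyl carbon gives a 1.2-fold higher number from compound 2 to compound 3 (0.07 log units; within the scatter), so the read-out does not separate these two ring sizes at this position. The wider exchange, from the group carrying no non-aromatic ring to the group carrying the six-membered one, gives a 1.8-fold higher number from compound 1 to compound 3 (0.25 log units; within the scatter), which is also within the scatter; together with the earlier step, this means that none of the three groups on the carbonyl carbon is separated from the others in this series. No measurement at hand bears on why these groups read alike.

Open, on these data alone, is whether a group of another kind on the carbonyl carbon, such as a plain phenyl ring or a seven-membered non-aromatic ring of carbon only, would move the number beyond the scatter. Equally open, as far as these compounds go, is whether a change elsewhere on the shared core, such as a carboxylic acid or a longer chain, would do so where these exchanges on the carbonyl carbon have not.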